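Benzanilide series against HSP60/HSP10: removing one bromo group

The source may hold more compounds than are shown below. What is called first, only, known or untested is meant among the compounds shown, and "the series" means these compounds.

Measured so far:
compound 1, `O=C(Nc1cccc(Cl)c1)c1cccc(Br)c1` — > 100000 nM
compound 2, `COc1ccccc1C(=O)Nc1cccc(Cl)c1` — > 100000 nM
compound 3, `COc1c(Br)cc(Br)cc1C(=O)Nc1cccc(Cl)c1` — > 100000 nM

In an assay for inhibition of HSP60/HSP10 (Homo sapiens), with a stated time of 60 min (on this read-out lower numbers stand for stronger inhibition and higher numbers for weaker inhibition), compound 1 gives only a limit, > 100000 nM. Compound 2 likewise gives a limit in this assay, > 100000 nM. Compound 3 also sits at a limit in this assay, > 100000 nM. Compound 3 therefore stands nowhere that can be ordered against the other two: all three values shown are limits, and they rest on the same mark, (the limit of > 100000 nM in this assay, at which 3 of the 3 values shown sit). For the measured compounds named here, no pair of measured compounds differs in a single place, so no measured step is available in this assay.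

Compound 4 is `COc1ccc(Br)cc1C(=O)Nc1cccc(Cl)c1`. Against compound 3 the change is hydrogen in place of bromo on an aromatic carbon, in words a hydrogen in place of bromo on an aromatic carbon. Compound 2, carrying no bromo at all, and compound 1, carrying one bromo, both sit at the limit, so for this change no step beyond the usual scatter is expected in this assay, in either direction. Compound 4 is estimated at 150000 nM in this assay, within 50000 nM to 500000 nM, most likely reported again as a limit. The expected step from compound 3 to compound 4 is a step that the limit leaves unreadable from compound 3 to compound 4.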

Compound 4, half-maximal inhibitory concentration: > 100000 nM
Compound 4 gave a limit, no number; the forecaster's own chance of this, stated with the estimate: 85%; the middle value lies beyond the limit too.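

Compound 4 gives only a limit in this assay, as do compound 1, compound 2 and compound 3, so no step to compound 4 can be read from any of them: the limit of > 100000 nM in this assay, at which 4 of the 4 values shown sit.

The compounds shown leave open whether any change on the shared core gives a value in this assay that can be read as a number.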